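Two compounds at the assay limit, one still unmeasured

The compounds below may be only part of what the source reports. "The series", "measured", "known", "first", "only" and "open" are said of these compounds alone.

Compound 1 `Cn1c(-c2ccccc2)nnc1S(C)(=O)=O`: > 200 mg/kg
Compound 2 `Cn1c(-c2ccccc2F)nnc1[S+](C)[O-]`: > 200 mg/kg

In a functional assay on the whole organism for antagonist activity, with Mus musculus as the target (a higher number here means that more compound is needed for the effect, a lower number that less compound is needed), compound 2 gives > 200 mg/kg, which is a limit and not a number. Compound 1 gives > 200 mg/kg, also a limit. Compound 3 `Cn1c(-c2ccccc2F)nnc1S(C)(=O)=O` keeps the core of compound 2 and changes one group on an aromatic carbon: a group of 4 heavy atoms (1 carbon, 2 oxygen, 1 sulfur; no ring) in place of a group of 3 heavy atoms (1 carbon, 1 oxygen, 1 sulfur; no ring), on an aromatic carbon. Within the data shown here, no measured step guides this change, so a modest move toward less compound needed in this assay is expected, though compound 3 may also stay at the limit. The expected size is an at least 2.5-fold lower number from compound 2 to compound 3 (0.39 log units; beyond the scatter). Compound 3 is estimated at 80 mg/kg, with an expected range of 20 mg/kg to 250 mg/kg.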

Compound 3, dose for half-maximal effect: > 100 mg/kg
Compound 3: no number, only a limit; the forecaster's own chance of this, stated with the estimate: 40%; middle value at least 1.2-fold (0.09 log units) away from the limit.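

Among these compounds, compound 1, compound 2 and compound 3 all give limits and not numbers, and no step between them can be read. On these data alone, what stays open is how much of any of them the effect actually needs, and whether swapping in the methylsulfonyl or fluoro group changes that amount.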